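Fluoro for Chloro on the Aryl Ring of Compound 3

This account rests on a few compounds, and the source may have more. Where it says the series, first, only, none or still open, it means among the compounds named here.

Three compounds sharing one core differ only in the aryl group on the thiazole. Compound 1 `Cc1nc(-c2cccc3ccccc23)sc1COc1ccc2c(c1)OCC2CC(=O)O` carries naphthalen-1-yl and in a functional assay on CHO cells for agonist activity at Free fatty acid receptor 1 (Homo sapiens), read by FLIPR and calcium flux, tested at 100 nM (on this read-out higher numbers stand for a stronger effect at the one concentration tested and lower numbers for a weaker effect), compound 1 gives 8.53%. Compound 2 `Cc1ccccc1-c1nc(C)c(COc2ccc3c(c2)OCC3CC(=O)O)s1` carries 2-methylphenyl and in this assay compound 2 gives 10.7%; the step of a number 2.2 percentage points higher from compound 1 to compound 2 (within the scatter) lies within the scatter. Compound 3 `Cc1nc(-c2cccc(Cl)c2)sc1COc1ccc2c(c1)OCC2CC(=O)O` carries 3-chlorophenyl and in this assay compound 3 gives 43%, the highest of the three numbers, with a number 34.5 percentage points higher from compound 1 to compound 3 (beyond the scatter) and a number 32.3 percentage points higher from compound 2 to compound 3 (beyond the scatter) both beyond the scatter.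

Compound 4 `Cc1nc(-c2cccc(F)c2)sc1COc1ccc2c(c1)OCC2CC(=O)O` has not yet been measured. It differs from compound 3 by fluoro in place of chloro on an aromatic carbon. Within the data shown here, no measured pair shows this exchange of one halogen for another; the measured steps of a number 34.5 percentage points higher from compound 1 to compound 3 (beyond the scatter) and a number 32.3 percentage points higher from compound 2 to compound 3 (beyond the scatter) only show that replacing the whole aryl group can move the read-out a great deal. Because compound 3 stands at 43% and the change here is confined to a single atom on the same ring, compound 4 is expected to stay nearer compound 3 than compounds 1 and 2, with a modest downward step of a number 13 percentage points lower from compound 3 to compound 4 (beyond the scatter). Compound 4 is therefore estimated at 30%, within a range from 10% to 55%.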

Compound 4, a percentage reported as activity, at one concentration (the size of the read-out at that concentration, not a potency): 56.9%
Estimate against measurement, compound 4: 26.9 percentage points below; the measured number lies above the stated range.
By their numbers in this assay, from the lowest: compounds 1 and 2 (each within the scatter of the next); then compound 3; then compound 4.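

In this assay, the exchange of fluoro for chloro on an aromatic carbon, meta to a large group, gives a number 13.9 percentage points higher from compound 3 to compound 4 (beyond the scatter), which shows that this place responds to the identity of a single halogen atom and not only to replacement of the whole aryl group. The 3-fluorophenyl group also sets compound 4 apart from the other two aryl variants, with a number 46.2 percentage points higher from compound 2 to compound 4 (beyond the scatter) and a number 48.4 percentage points higher from compound 1 to compound 4 (beyond the scatter), so that compound 4 has the highest number of the four, and both 3-chlorophenyl and 3-fluorophenyl stand clear of 2-methylphenyl and naphthalen-1-yl. No evidence at hand bears on why the halogen exchange moves the read-out in this direction.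

The compounds shown leave open whether the trend from chloro to fluoro would extend to bromo, or what hydrogen, methoxy, trifluoromethyl or nitrile would give in the same place on the ring. These numbers, each taken at a single concentration, give the size of the effect at that concentration, and they also leave open whether the stronger effect of compound 4 over compound 3 would persist across a full concentration range.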